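A few compounds are considered here, and "the series" means these few. Any claim that something is new, unique, unknown or untested is made for them only; others in the source may bear on it.

Working notes on the series in a functional assay on HCT-116 cells (Homo sapiens) for inhibition; on this read-out lower numbers stand for stronger inhibition and higher numbers for weaker inhibition.

Three compounds share one core and differ only in the group on one aromatic carbon of the five-membered ring with one nitrogen and one oxygen. Compound 1 `CCCNCc1cc(-c2c(C(=O)NCC)noc2-c2cc(C(C)C)c(O)cc2O)on1` gives 117 nM in this assay, the second highest of the three numbers. Compound 2 `CCNC(=O)c1noc(-c2cc(C(C)C)c(O)cc2O)c1-c1cc(CNC(=O)CC)no1` gives 78 nM and compound 3 `CCCN(CCC)Cc1cc(-c2c(C(=O)NCC)noc2-c2cc(C(C)C)c(O)cc2O)on1` gives 183 nM. The step of a 1.5-fold lower number from compound 1 to compound 2 (0.18 log units; within the scatter) and the step of a 1.6-fold higher number from compound 1 to compound 3 (0.19 log units; within the scatter) both stay within the scatter, while the step of a 2.3-fold higher number from compound 2 to compound 3 (0.37 log units; beyond the scatter) is a modest one beyond it; in all three the change is confined to the amine nitrogen or the saturated chain carbon, and the two five-membered rings are untouched.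

Compound 4 `CCNC(=O)c1noc(-c2cc(C(C)C)c(O)cc2O)c1-c1ccn(CC)n1` is not yet measured. It differs from compound 1 by 1-ethyl-1H-pyrazol-3-yl in place of 3-((propylamino)methyl)-1,2-oxazol-5-yl on an aromatic carbon; the whole 3-((propylamino)methyl)-1,2-oxazol-5-yl group leaves and a smaller 1-ethyl-1H-pyrazol-3-yl group with no hydrogen-bond donor enters in its place. Among the measured compounds shown here, no measured step exchanges a ring, so the three steps above bear on this change only indirectly: they show that varying the amine end moves the number little. For the ring exchange a step larger than those is possible in either direction, and the expected step of a 2.1-fold higher number from compound 1 to compound 4 (0.33 log units; beyond the scatter) is taken as a modest rise. Compound 4 is therefore expected to give about 250 nM, with a range from 80 nM to 800 nM.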

Compound 4, half-maximal inhibitory concentration: 25 nM
Compound 4: middle estimate off by 10-fold (1.00 log units), on the high side; measured number below the stated range.
By their numbers in this assay, from the lowest: compound 4; then compounds 2, 1 and 3 (each within the scatter of the next, the first and the last beyond it).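

In this assay, the exchange of the whole 3-((propylamino)methyl)-1,2-oxazol-5-yl group for 1-ethyl-1H-pyrazol-3-yl gives a 4.7-fold lower number from compound 1 to compound 4 (0.67 log units; beyond the scatter), a step larger than any seen while only the amine end was varied. Among the compounds shown here, this position on the shared core therefore responds more to exchange of the whole group than the earlier steps showed, and stronger inhibition here does not depend on the propylamino chain or on a hydrogen-bond donor in the group, as the entering group is smaller and has none. No measurement in hand bears on what lies behind this step.

For the compounds shown here, the single step changes the ring and its substituent together, so the share of each remains unresolved, and a 1-ethyl-1H-pyrazol-3-yl group carrying a propylaminomethyl chain would help to separate them. As far as these compounds go, how closely the number follows the group on the ring nitrogen is also open, and 1-methyl-1H-pyrazol-3-yl or 1-propyl-1H-pyrazol-3-yl would test this against the 1-ethyl group.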